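From compound 3 to the plain phenyl compound 4

The compounds below may be only part of what the source reports. "The series", "measured", "known", "first", "only" and "open" are said of these compounds alone.

In a functional assay on Malme-3M cells (Homo sapiens) for inhibition, read by sulforhodamine B assay, with a stated time of 48 h (on this read-out lower numbers stand for stronger inhibition of growth and higher numbers for weaker inhibition of growth), compound 2 `COc1cc(-c2nn(-c3cccc(NC(=O)Nc4cccc(C(F)(F)F)c4)c3)cc2-c2ccncc2)ccc1Cl` gives 2410 nM and compound 3 `COc1cc(-c2nn(-c3cccc(NC(=O)c4ccc(Cl)c(C(F)(F)F)c4)c3)cc2-c2ccncc2)ccc1Cl` gives 19700 nM, the higher of these two numbers. Compound 1 `COc1cc(-c2nn(-c3cccc(NC(=O)c4cccc(C(F)(F)F)c4)c3)cc2-c2ccncc2)ccc1Cl` reads > 50000 nM, which is a limit of the assay and not a number. Compound 4 `COc1cc(-c2nn(-c3cccc(NC(=O)c4ccccc4)c3)cc2-c2ccncc2)ccc1Cl` carries phenyl in place of 4-chloro-3-(trifluoromethyl)phenyl on a carbonyl carbon. The step that bears most directly is the one adding chloro, an at least 2.5-fold lower number from compound 1 to compound 3 (0.40 log units; beyond the scatter), and compound 4 gives that chloro up and loses the trifluoromethyl as well. A modest move toward weaker inhibition is therefore expected in this assay, estimated as a 2.3-fold higher number from compound 3 to compound 4 (0.36 log units; beyond the scatter). For compound 4 the estimated value is 45000 nM, with an expected range of 20000 nM to 100000 nM.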

Compound 4, concentration for total growth inhibition: > 100000 nM
Compound 4 ended at the assay's limit; the forecaster's own chance of this, stated with the estimate: 65%; middle value at least 2.2-fold (0.34 log units) away from the limit.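

Replacing 4-chloro-3-(trifluoromethyl)phenyl on this carbonyl carbon with plain phenyl weakens inhibition in this assay, with an at least 5.0-fold higher number from compound 3 to compound 4 (0.70 log units; beyond the scatter), and replacing (3-(trifluoromethyl)phenyl)amino with phenyl costs more, with an at least 41-fold higher number from compound 2 to compound 4 (1.61 log units; beyond the scatter). The reading for compound 4 is a limit of the assay and not a number: the limit of > 100000 nM in this assay, at which 1 of the 4 values shown sits. The step between compound 1 and compound 4 cannot be read, as both values are limits.

As far as these compounds go, what trifluoromethyl contributes alone on this ring therefore stays open. Also open, from the compounds shown here alone, is how an amine or a carboxylic acid in place of the chloro would read.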